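This account rests on a few compounds, and the source may have more. Where it says the series, first, only, none or still open, it means among the compounds named here.

Measured in an assay on HEK-293T cells for inhibition of diacylglycerol lipase-alpha (Homo sapiens), read by colorimetric assay; a lower number here means a stronger inhibitor, a higher number a weaker inhibitor:

Compound 1 `O=C(CCCCCc1ccccc1)c1nc2ccc([N+](=O)[O-])cc2o1` — 87.1 nM
Compound 2 `COc1coc(C(=O)CCCCCCc2ccccc2)n1` — only a limit of the assay, > 10000 nM
Compound 3 `O=C(CCCCCCCCc1ccccc1)c1nc2ncccc2o1` — 3.63 nM

Of the two numbers in hand, compound 3 has the lowest. The nearest is compound 1, whose value stands well beyond the scatter from that of compound 3, so compound 3 is the stronger of the two by a clear margin. Compound 2 reaches only the limit of > 10000 nM in this assay, at which 1 of the 3 values shown sits, and gives no number to compare.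

Compound 4 `CCCCCCCCCCCCCC(=O)c1nc2ncccc2o1` has not yet been measured. It differs from compound 3 in one place: pentyl in place of phenyl on a saturated chain carbon, eight bonds along the chain from a carbonyl carbon. Within the data shown here, no measured pair in this set makes exactly this change, so the expectation for compound 4 rests on the standing of compound 3 alone. The chain keeps its length and its carbonyl, and the shared core is unchanged; the end of the chain loses a ring and gains an open pentyl. Without a measured step of this kind, the expected change in this assay is small, in either direction, and most likely not beyond the scatter, with a slight lean toward a weaker inhibitor.

Compound 4 is therefore estimated at 6 nM, with a likely range from 1.5 nM to 30 nM. This estimate amounts to an expected step of a 1.7-fold higher number from compound 3 to compound 4 (0.22 log units; within the scatter).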

Compound 4, half-maximal inhibitory concentration: 74.1 nM
Estimate against measurement, compound 4: 12-fold (1.09 log units) below, outside the stated range (above it).
By their numbers in this assay, from the lowest: compound 3; then compounds 4 and 1 (each within the scatter of the next). At a limit, above all of these: compound 2.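

Replacing phenyl with pentyl on a saturated chain carbon, eight bonds along the chain from a carbonyl carbon, gives a 20-fold higher number from compound 3 to compound 4 (1.31 log units; beyond the scatter) in this assay, so the far end of the chain is not an indifferent place, even though the shared core and the carbonyl stay the same. Neither group carries a hydrogen-bond donor, a hydrogen-bond acceptor or a net charge, and the clear counted difference between them is the six-membered aromatic ring of carbon only, so in this single pair the ring goes with the lower number, while compound 4 still gives a measurable 74.1 nM without it. Nothing among the data shown bears on what lies behind this step.

Among these compounds, only this one pair speaks to the end of the chain, so it remains open whether a cyclohexyl ring or a pyridine ring there would hold the number of compound 3, which would separate the presence of a ring from its aromatic character. From the compounds shown here alone, the effect of an amine or a carboxylic acid at the chain end also remains open.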